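Removing a Methyl Branch: Expected Response of Compound 3

The compounds below may be only part of what the source reports. "The series", "measured", "known", "first", "only" and "open" are said of these compounds alone.

Compound 1, `CC(C)CCCc1nc(O)cc(O)n1`: in a functional assay on HEK293 cells for agonist activity at G-protein coupled receptor 84 (Homo sapiens), read by calcium flux (a higher number here means a larger maximal response, a lower number a smaller maximal response), compound 1 gives 85.6%.
Compound 2, `CCCCCCCC(C)c1nc(O)cc(O)n1`: in this assay compound 2 gives 103%.

Both compounds share the same core and differ only in the saturated chain attached to it. Compound 2 stands highest of the two numbers; the nearest value, that of compound 1, lies lower by an amount beyond the usual scatter of this kind of measurement.

Compound 3, `CCCCCCCCc1nc(O)cc(O)n1`, has not yet been measured in this assay. Relative to compound 2 it shows one change: hydrogen in place of methyl on a saturated chain carbon bound to an aromatic carbon and a saturated chain carbon. The rest of the molecule is unchanged.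

Going by the values given here, no measured step of this kind is available, so the expectation rests on the closeness of the two structures. The step is expected to be a number 8 percentage points lower from compound 2 to compound 3 (within the scatter), at most a small decrease and likely within the scatter. For compound 3 the expected maximal response is 95%, with a range from 75% to 110%.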

Compound 3, largest response reached (reported as percent of maximum), in percent of the reference or control that the assay uses: 110%
Beside the measured number, compound 3's estimate is 15 percentage points below it, and the stated range covers the measured number.
By their numbers in this assay, from the lowest: compound 1; then compounds 2 and 3 (each within the scatter of the next).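

In this assay, hydrogen in place of methyl on the saturated chain carbon bound to an aromatic carbon and a saturated chain carbon gives a number 7 percentage points higher from compound 2 to compound 3 (within the scatter), so in this pair the methyl branch is not required for the maximal response. Pentyl in place of isopropyl on a saturated chain carbon, three bonds along the chain from an aromatic carbon, gives a number 24.4 percentage points higher from compound 1 to compound 3 (beyond the scatter), a modest step that shows the far end of the chain can shift the response by more than the scatter. Nothing at hand explains why either step has the size it has.

Going by these compounds, whether a longer chain, a cyclohexyl group or a terminal carboxylic acid at the end of the chain would keep this response remains open. The maximal response also leaves open how much of each compound is needed to reach it.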